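This account rests on a few compounds, and the source may have more. Where it says the series, first, only, none or still open, it means among the compounds named here.

Three compounds share one core, and each carries a different group on an aromatic nitrogen of its five-membered aromatic ring with three nitrogen atoms. In a functional assay on HCT-116 cells (Homo sapiens) for inhibition, read by MTT assay, with a stated time of 72 h (a lower number here means a stronger inhibitor of growth, a higher number a weaker inhibitor of growth), compound 1 `N#Cc1ccc(Cn2cc(C[C@H](O)COCCOC[C@@H](O)Cc3ccc(-c4ccccc4)cc3)nn2)cc1` gives 8800 nM. Compound 2 `O=C1COc2ccc(-n3cc(C[C@H](O)COCCOC[C@@H](O)Cc4ccc(-c5ccccc5)cc4)nn3)cc2N1` gives 42500 nM in this assay. Compound 3 `O[C@H](COCCOC[C@@H](O)Cc1cn(Cc2ccc(C(F)(F)F)cc2)nn1)Cc1ccc(-c2ccccc2)cc1` gives 2500 nM, the lowest of the three numbers, and it is the strongest growth inhibitor here, since its steps to the others lie beyond the scatter: a 3.5-fold lower number from compound 1 to compound 3 (0.55 log units; beyond the scatter) and a 17-fold lower number from compound 2 to compound 3 (1.23 log units; beyond the scatter).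

Compound 4 `O[C@H](COCCOC[C@@H](O)Cc1c[nH]nn1)Cc1ccc(-c2ccccc2)cc1` keeps the core but shows (hydrogen in place of 4-(trifluoromethyl)benzyl on an aromatic nitrogen). Within the data shown here, none of the measured steps strips this nitrogen bare; the three that alter the group there, including a 4.8-fold higher number from compound 1 to compound 2 (0.68 log units; beyond the scatter), show that what sits on it moves the number in both directions, and the trifluoromethyl-bearing group gave the lowest value. Removing it entirely is a bigger change than any tried, so a weaker inhibitor is expected: an 8.0-fold higher number from compound 3 to compound 4 (0.90 log units; beyond the scatter). Compound 4 is estimated at 20000 nM, with a range from 5000 nM to 80000 nM.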

Compound 4, concentration for 50% growth inhibition: > 100000 nM
Compound 4 ended at the assay's limit; the forecaster's own chance of this, stated with the estimate: 20%; middle value at least 5.0-fold (0.69 log units) from the limit.
By their numbers in this assay, from the lowest: compound 3; then compound 1; then compound 2. At a limit, above all of these: compound 4.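

In this assay, compound 4 gives a limit of the assay and not a number: the limit of > 100000 nM in this assay, at which 1 of the 4 values shown sits. Replacing the whole group on this aromatic nitrogen with hydrogen gives a weaker inhibitor than any of the three groups measured there, even the group of compound 2: an at least 2.3-fold higher number from compound 2 to compound 4 (0.37 log units; beyond the scatter), alongside an at least 11-fold higher number from compound 1 to compound 4 (1.05 log units; beyond the scatter) and an at least 40-fold higher number from compound 3 to compound 4 (1.60 log units; beyond the scatter). The earlier steps showed only that changing the group moves the number, whereas this change shows that, among these four compounds, every measured number belongs to a compound with a group on this nitrogen.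

From the compounds shown here alone, it remains open whether a group as small as methyl, or a plain benzyl, would bring back a measurable number. Going by these compounds, it is also open how a carboxylic acid or an amine in place of trifluoromethyl on the benzyl ring would compare with compound 3.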